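Thiazolyl in Place of Halogenated Aryl on a Catechol Amide

The source may report more compounds than this note shows. Statements on the series, on what has been measured and on what is new or still open speak of the compounds shown alone.

Measured so far in an assay on isolated protein for inhibition of phosphodiesterase 4A (Sus scrofa); on this read-out higher numbers stand for weaker inhibition and lower numbers for stronger inhibition:
Compound 1 `COc1ccc(C(=O)Nc2cccc(Cl)c2Cl)cc1OC1CCCC1`, a limit only: > 200000 nM
Compound 2 `COc1ccc(C(=O)Nc2c(F)cccc2Cl)cc1OC1CCCC1`: 240 nM
Compound 3 `COc1ccc(C(=O)Nc2ccccc2Cl)cc1OC(=O)c1ccccc1`, a limit only: > 1000000 nM

Among the compounds with values here, compound 2 is the only compound here with an actual number in this assay; the other two give limits rather than numbers. Compound 1 sits at the limit of > 200000 nM in this assay, at which 1 of the 3 values shown sits. Compound 3 sits at the limit of > 1000000 nM in this assay, at which 1 of the 3 values shown sits. Within the data shown here, the one step between measured compounds, an at least 830-fold lower number from compound 1 to compound 2 (2.92 log units; beyond the scatter), shows that the group on the amide nitrogen can swing inhibition by a very large margin. Compound 4 `COc1ccc(C(=O)Nc2nccs2)cc1OC1CCCC1` differs from compound 2 in that same place: 1,3-thiazol-2-yl in place of 2-chloro-6-fluorophenyl on an amide-type nitrogen. Among the measured compounds shown here, no measured step involves a five-membered aromatic ring, so the only guidance is that the amide substituent matters greatly and that two of the three variants gave limits. Compound 4 is therefore expected to be weaker than compound 2, with the estimated step of a 13-fold higher number from compound 2 to compound 4 (1.10 log units; beyond the scatter) and wide uncertainty. The estimate for compound 4 in this assay is 3000 nM, expected to fall between 300 nM and 60000 nM.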

Compound 4, half-maximal inhibitory concentration: 6500 nM
Compound 4: the middle estimate sits 2.2-fold (0.34 log units) below what was measured; low and high end bracket the measured number.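

In this assay, the step of a 27-fold higher number from compound 2 to compound 4 (1.43 log units; beyond the scatter) shows that 1,3-thiazol-2-yl does not match 2-chloro-6-fluorophenyl on the amide-type nitrogen, whereas the step of an at least 30-fold lower number from compound 1 to compound 4 (1.48 log units; beyond the scatter) shows that it gives stronger inhibition than 2,3-dichlorophenyl. Among compound 1, compound 2 and compound 4, a halogenated six-membered ring is therefore neither needed for a measurable number nor enough to secure one, and the thiazolyl ring falls between the two halogenated rings. Compound 1 gives a limit rather than a number, so the second step is only a bound: the limit of > 200000 nM in this assay, at which 1 of the 4 values shown sits.

From the compounds shown here alone, what remains open is whether the ring size or the hetero atoms of 1,3-thiazol-2-yl set its level of inhibition. Pyridin-2-yl, 1,3-oxazol-2-yl or plain phenyl on the same core would help separate these two features.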